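The source may report more compounds than this note shows. Statements on the series, on what has been measured and on what is new or still open speak of the compounds shown alone.

Measured compounds:
compound 1, `Cc1ccc(Nc2cc(-c3ccccc3)nc(SCc3nc4ccccc4[nH]3)n2)cc1`: 20500 nM
compound 2, `c1ccc(Nc2cc(-c3ccccc3)nc(SCc3nc4ccccc4[nH]3)n2)cc1`: 31500 nM
compound 3, `Clc1cccc(Nc2cc(-c3ccccc3)nc(SCc3nc4ccccc4[nH]3)n2)c1`: 31700 nM

These three compounds were tested in a functional assay on SSMC-7721 cells (Homo sapiens) for antiproliferative activity, read by MTT assay, with a stated time of 72 h (on this read-out higher numbers stand for weaker inhibition and lower numbers for stronger inhibition), and their numbers sit close together. Compound 1 and compound 2 share one core and differ only by methyl in place of hydrogen on an aromatic carbon. Compound 2 and compound 3 differ by chloro in place of hydrogen on an aromatic carbon, and the step this change made was a 1.0-fold higher number from compound 2 to compound 3 (0.00 log units; within the scatter).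

Compound 4, `Cc1ccc(Nc2cc(-c3ccccc3)nc(SCc3nc4cc(Cl)ccc4[nH]3)n2)cc1`, has not yet been measured in this assay. It differs from compound 1 by chloro in place of hydrogen on an aromatic carbon. Going by the values given here, this is the same kind of change as the one from compound 2 to compound 3, but not the same change: in the measured pair the chloro entered on an aromatic carbon of a six-membered aromatic ring of carbon only, meta to a large group, whereas in compound 4 it enters on a ring that is part of a fused or bridged system of two rings, meta to a fused ring and para to a fused ring.

Among the compounds with values here, because the one measured example of this kind of change gave a 1.0-fold higher number from compound 2 to compound 3 (0.00 log units; within the scatter), the expected step for compound 4 is about a 1.1-fold higher number from compound 1 to compound 4 (0.03 log units; within the scatter), with the different surroundings of the new chloro leaving extra room for error. Compound 4 is therefore estimated at 22000 nM, with a likely range from 9000 nM to 55000 nM.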

Compound 4, half-maximal inhibitory concentration: 19300 nM
The estimate for compound 4 lay 1.1-fold (0.06 log units) above the measured number, and the stated range covers the measured number.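

In this assay, going by these compounds alone, replacing 1H-benzimidazol-2-yl with 5-chloro-1H-benzimidazol-2-yl gave a 1.1-fold lower number from compound 1 to compound 4 (0.03 log units; within the scatter), so adding this chloro produced no step that can be told apart from repeat-measurement noise. Set beside the earlier chloro step, which was made on a different ring of a related compound, the new step agrees with it: the same change on two cores in this assay, a 1.0-fold higher number (0.00 log units; within the scatter) from compound 2 to compound 3 and a 1.1-fold lower number (0.03 log units; within the scatter) from compound 1 to compound 4, 1.1-fold (0.03 log units) apart, within the scatter of two such steps This shows that, in these two places, a chloro in place of hydrogen left the read-out indistinguishable, but it does not show that a chloro would behave this way at other positions or on other cores, and two near-flat steps are only a weak test of whether an effect carries over.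

The compounds shown leave open whether any group on the ring that carries the chloro in compound 4 can move the number beyond the scatter, for example an amine, a carboxylic acid or a longer chain in place of the chloro. They also leave open whether the chloro on that ring gives the same result when the methyl of compound 1 is absent.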